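The compounds below may be only part of what the source reports. "The series", "measured", "known", "first", "only" and "open" are said of these compounds alone.

Working notes on the series.

Compound 1 `COC(=O)[C@@]1(C)CCC=C2[C@@H]1CC[C@@H](C)[C@]2(C)Cc1c[nH]c2ccccc12` is the reference. In a functional assay on T47D cells (Homo sapiens) for inhibition, read by sulforhodamine B assay, with a stated time of 48 h (on this read-out lower numbers stand for stronger inhibition of growth and higher numbers for weaker inhibition of growth), compound 1 gives 4200 nM. Within the data shown here, compound 2 `COC(=O)[C@@]1(C)CCC=C2[C@@H]1CC[C@@H](C)[C@]2(C)Cc1c(C)[nH]c2ccccc12` carries the change (methyl in place of hydrogen on an aromatic carbon), and in this assay compound 2 gives 17000 nM; the step of a 4.0-fold higher number from compound 1 to compound 2 (0.61 log units; beyond the scatter) is the only measured methyl-for-hydrogen step available.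

Compound 3 `COC(=O)[C@@]1(C)CC[C@@H]2C3=C1CC[C@@H](C)[C@]3(C)C[C@@H]1c3ccccc3N[C@H]21` has the same atoms as compound 1 joined differently; the difference between the two cores is not broken down here. In this assay compound 3 gives 35000 nM, the highest of the three numbers, beyond the scatter from both compound 2 and compound 1.

Compound 4 `COC(=O)[C@@]1(C)CC[C@@H]2C3=C1CC[C@@H](C)[C@]3(C)C[C@@H]1c3cc(C)ccc3N[C@H]21` is not yet measured and differs from compound 3 by methyl in place of hydrogen on an aromatic carbon. Among the measured compounds shown here, this is the same kind of change as the one from compound 1 to compound 2, but not the same change: in compound 2 the methyl sits on an aromatic carbon of a five-membered aromatic ring with one nitrogen, part of a fused or bridged system of two rings, next to the ring nitrogen and next to the ring atom that bears a large group, whereas in compound 4 it sits on an aromatic carbon of a six-membered aromatic ring of carbon only, part of a fused or bridged system of five rings, meta to a fused ring and para to a fused ring.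

For compound 4 the expected step in this assay is a 1.7-fold higher number from compound 3 to compound 4 (0.23 log units; within the scatter). For the measured compounds named here, this expectation rests on the one measured methyl step because a 4.0-fold higher number from compound 1 to compound 2 (0.61 log units; beyond the scatter) was modest, tempered by the different place, which is expected to blunt any effect. Compound 4 is estimated at 60000 nM, within 25000 nM to 150000 nM.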

Compound 4, concentration for 50% growth inhibition: 23000 nM
Compound 4: the middle estimate sits 2.6-fold (0.42 log units) above what was measured; the whole stated range lies above it.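

In this assay, the new step is a 1.5-fold lower number from compound 3 to compound 4 (0.18 log units; within the scatter), so on this core the added methyl leaves the number within the scatter. Methyl in place of hydrogen on an aromatic carbon therefore does not carry over with a fixed size from one core to the other: the same change on two cores in this assay, a 4.0-fold higher number (0.61 log units; beyond the scatter) from compound 1 to compound 2 and a 1.5-fold lower number (0.18 log units; within the scatter) from compound 3 to compound 4, 6.2-fold (0.79 log units) apart, beyond the scatter of two such steps. This does not show what sets the gap, since the methyl of compound 4 sits on an aromatic carbon of a six-membered aromatic ring of carbon only and the methyl of compound 2 on a five-membered aromatic ring with one nitrogen, so core and place change together, and two steps give no rule for any further core.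

Open, going by these compounds, is whether chlorine, a methoxy group or an amine on the same aromatic carbon of compound 3 would move the number beyond the scatter, and whether the same groups on the ring carbon that carries the methyl in compound 2 would behave as that methyl does. On these data alone, all four compounds keep the methyl ester, so the effect of a carboxylic acid or an amide at that place on either core also remains open.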